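The compounds below may be only part of what the source reports. "The series", "measured", "known", "first", "only" and "open" are said of these compounds alone.

Compound 3 `NC(=O)c1ccc(-c2cccnc2)cc1OC1CCCCC1` gives 1500 nM in an assay on cells for inhibition of MAP kinase-interacting serine/threonine-protein kinase 1 (Homo sapiens), read by mobility shift assay, with stated times of 10 min and 60 min, in the presence of a further agent that is not named here (a lower number here means a stronger inhibitor, a higher number a weaker inhibitor), and stands second highest of the three measured compounds; its nearest neighbour is compound 2 `NCCOc1cc(-c2cccnc2)ccc1C(N)=O`, which gives 820 nM, and its furthest is compound 1 `Cc1cc(-c2cccnc2)ccc1C(N)=O`, which gives 22000 nM. Compound 4 `NC(=O)c1ccc(-c2cccnc2)cc1O` differs from compound 3 by hydrogen in place of cyclohexyl on an oxygen on an aromatic ring. Among the compounds with values here, the steps that bear on this are a 15-fold lower number from compound 1 to compound 3 (1.17 log units; beyond the scatter) and a 27-fold lower number from compound 1 to compound 2 (1.43 log units; beyond the scatter), both large drops on replacing methyl with a substituted oxygen, whereas a 1.8-fold higher number from compound 2 to compound 3 (0.26 log units; within the scatter) leaves the two oxygen substituents within the scatter of each other. Stripping the cyclohexyl away runs in the reverse sense of those drops, so a large rise is expected for compound 4, a 5.3-fold higher number from compound 3 to compound 4 (0.73 log units; beyond the scatter). The estimate for compound 4 is 8000 nM, with a range from 2500 nM to 25000 nM.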

Compound 4, half-maximal inhibitory concentration: 4300 nM
For compound 4 the middle estimate is 1.9-fold (0.27 log units) above the measured one; the measured number falls inside the stated range.
By their numbers in this assay, from the lowest: compounds 2 and 3 (each within the scatter of the next); then compound 4; then compound 1.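

In this assay the free hydroxy stands apart from both substituted oxygens, with a 2.9-fold higher number from compound 3 to compound 4 (0.46 log units; beyond the scatter) on losing cyclohexyl and a 5.2-fold higher number from compound 2 to compound 4 (0.72 log units; beyond the scatter) on losing 2-aminoethyl. It still keeps part of the gain over methyl, with a 5.1-fold lower number from compound 1 to compound 4 (0.71 log units; beyond the scatter), so part of that gain comes with the oxygen alone and the rest with a group on it. Nothing measured here explains this. As far as these compounds go, whether a methoxy group, a longer chain ending in an amine, or a carboxylic acid on this oxygen would give a lower number than compound 2 and compound 3 stays open.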